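The compounds below may be only part of what the source reports. "The series", "measured", "known", "first", "only" and "open" are said of these compounds alone.

Measured so far:

- compound 1 `Cc1ccc(/C=C2\CCC/C(=C\c3ccc([N+](=O)[O-])cc3)C2=O)cc1` gives 8160 nM in a functional assay on L1210 cells (Mus musculus) for cytotoxicity, with a stated time of 48 h; on this read-out higher numbers stand for weaker inhibition and lower numbers for stronger inhibition
- compound 2 `COc1cc(/C=C2\CCC/C(=C\c3cccc([N+](=O)[O-])c3)C2=O)cc(OC)c1OC` gives 42200 nM in this assay
- compound 3 `O=C1CCCC/C1=C\c1ccc([N+](=O)[O-])cc1` gives 46500 nM in this assay

All three compounds share a ring-ketone core carrying nitro-substituted aromatic arms, and all were tested in this assay. Compound 1 has the lowest number of the three, which on this read-out means the strongest inhibition. Compound 2 and compound 3 both stand clearly higher, and in each case the gap to compound 1 lies beyond the usual scatter of repeated measurements, so compound 1 can be called the most active of the three.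

Compound 4 `COc1ccc(/C=C2\CCC/C(=C\c3ccc([N+](=O)[O-])cc3)C2=O)cc1` has not yet been measured. It differs from compound 1 in a single place: methoxy in place of methyl on an aromatic carbon. For the measured compounds named here, no two measured compounds differ from each other in just this way, so there is no measured step that shows what such a swap does here. The change is small and sits at the outer edge of the molecule, so the expectation is a step in this assay that stays within the scatter, with no clear direction.

Compound 4 is therefore expected to give about 7500 nM, with a likely range from 2500 nM to 22000 nM. The expected step of a 1.1-fold lower number from compound 1 to compound 4 (0.04 log units; within the scatter) is, in other words, essentially no change.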

Compound 4, half-maximal inhibitory concentration: 240000 nM
The estimate for compound 4 lay 32-fold (1.51 log units) below the measured number, and the stated range ends below it.
By their numbers in this assay, from the lowest: compound 1; then compounds 2 and 3 (each within the scatter of the next); then compound 4.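

This place, para to a large group, proved sensitive in this assay: going from 4-methylphenyl to 4-methoxyphenyl gives a 29-fold higher number from compound 1 to compound 4 (1.47 log units; beyond the scatter), so bringing in a single oxygen along with the methyl carbon is enough to weaken inhibition well beyond the scatter. For the compounds shown here, the earlier compounds could not show this, since no two of them differ in just one place, and this is the first measured step that isolates a single change on the shared core. Nothing available bears on why a swap this small produces a step this large.

The compounds shown leave open whether the loss follows from the oxygen itself or from the whole methoxy group, which a hydroxy group, an ethyl group or a chlorine atom at this place could help separate. They also leave open whether the same swap has a similar effect with another group in place of the nitro group on the second aromatic arm, such as an amine, or whether this step holds only for the arrangement in compound 1.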